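Methyl for chloro on the aryl ketone of compound 3

The compounds below may be only part of what the source reports. "The series", "measured", "known", "first", "only" and "open" are said of these compounds alone.

Three members of the series have been tested in an ADME assay on HEK293 cells (Homo sapiens) for antiproliferative activity, read by MTT assay, with a stated time of 24 h; on this read-out lower numbers stand for stronger inhibition and higher numbers for weaker inhibition. Compound 1 `COc1ccc(-c2cc(/C=C/C(=O)c3ccc(OC)c(OC)c3)nc3cc(-c4ccccc4)nn23)cc1` gives 48500 nM; compound 2 `COc1ccc(C(=O)/C=C/c2cc(-c3ccc(OC)c(OC)c3)n3nc(-c4ccccc4)cc3n2)cc1` gives 40000 nM; compound 3 `COc1ccc(-c2cc(/C=C/C(=O)c3ccc(Cl)cc3)nc3cc(-c4ccccc4)nn23)cc1OC` gives 44100 nM. Compound 3 stands second highest of the three numbers, but its nearest neighbour is compound 1 and its furthest is compound 2, and both gaps are within the scatter, so no order among the three can be read.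

Compound 4 `COc1ccc(-c2cc(/C=C/C(=O)c3ccc(C)cc3)nc3cc(-c4ccccc4)nn23)cc1OC` differs from compound 3 in one place: methyl in place of chloro on an aromatic carbon. Within the data shown here, the only step so far at that same position is the exchange of methoxy for chloro, which gave a 1.1-fold higher number from compound 2 to compound 3 (0.04 log units; within the scatter), within the scatter. Among the measured compounds shown here, no step from chloro to methyl has been measured, so the expectation rests on that single neighbouring change and on the narrow spread of all three numbers.

The step from compound 3 to compound 4 in this assay is therefore expected to be a 1.0-fold lower number from compound 3 to compound 4 (0.00 log units; within the scatter), nothing beyond the scatter. Compound 4 is estimated at 44000 nM, with a range from 22000 nM to 88000 nM.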

Compound 4, half-maximal inhibitory concentration: 62600 nM
Beside the measured number, compound 4's estimate is 1.4-fold (0.15 log units) below it; the measured number falls inside the stated range.
By their numbers in this assay, from the lowest: compounds 2, 3, 1 and 4 (each within the scatter of the next).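

In this assay, going from (4-chlorophenyl)carbonyl to (4-methylphenyl)carbonyl gives a 1.4-fold higher number from compound 3 to compound 4 (0.15 log units; within the scatter) and methyl in place of methoxy gives a 1.6-fold higher number from compound 2 to compound 4 (0.19 log units; within the scatter), so methyl can now be compared with both earlier groups on this aromatic carbon. Together with a 1.1-fold higher number from compound 2 to compound 3 (0.04 log units; within the scatter), these steps show that methoxy, chloro and methyl cannot be put in any order here, as all three steps lie within the scatter. Nothing at hand bears on the cause of these small steps.

Going by these compounds, whether an amine, a carboxylic acid or a longer alkyl chain on this aromatic carbon would produce a step beyond the scatter remains open. On these data alone, all the numbers here also come from a single assay, so it is open whether methyl and chloro would stay this close in any other read-out.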